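Cytotoxicity on Vero cells across hydrazone variants

A few compounds are considered here, and "the series" means these few. Any claim that something is new, unique, unknown or untested is made for them only; others in the source may bear on it.

Measured compounds:
Compound 1, `COc1ccc(/C=N/NC(=O)c2cnc3c(C(F)(F)F)cccc3c2N[C@@H](CSc2ccccc2)CC(=O)N(C)C)cc1O`: in an ADME assay on Vero cells (Chlorocebus sabaeus) for cytotoxicity, read by MTT assay, with a stated time of 72 h (on this read-out lower numbers stand for stronger inhibition and higher numbers for weaker inhibition), compound 1 gives > 62.5 ug/mL, a limit of the assay and not a number.
Compound 2, `CN(C)C(=O)C[C@H](CSc1ccccc1)Nc1c(C(=O)N/N=C/c2ccccc2F)cnc2ccc(F)cc12`: in this assay compound 2 gives > 62.5 ug/mL, again a limit of the assay.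

Among the measured compounds shown here, compound 2 thus stands at the upper edge of what this assay can report, and the only other value shown sits at the same edge: the limit of > 62.5 ug/mL in this assay, at which 2 of the 2 values shown sit. For the measured compounds named here, no step between measured compounds is available, so nothing quantifies any change.

Compound 3, `CN(C)C(=O)C[C@H](CSc1ccccc1)Nc1c(C(=O)N/N=C/c2ccc(F)cc2)cnc2ccc(F)cc12`, differs from compound 2 in one place: 4-fluorophenyl in place of 2-fluorophenyl on a carbon with a double bond to nitrogen. With both measured values at a limit, the expectation for this assay is no step beyond the usual scatter, in either direction.

For compound 3 the estimated value in this assay is 80 ug/mL, with a range from 40 ug/mL to 200 ug/mL. The expected step that the limit leaves unreadable from compound 2 to compound 3 is none beyond scatter.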

Compound 3, half-maximal inhibitory concentration: > 62.5 ug/mL
Compound 3 was reported as a limit; the forecaster's own chance of this, stated with the estimate: 85%; the middle value lies beyond the limit too.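

Among the compounds shown here, compound 3 is reported as a limit, as compound 2 is, so no step from compound 2 to compound 3 can be read: the limit of > 62.5 ug/mL in this assay, at which 3 of the 3 values shown sit. The compounds shown leave open whether any hydrazone variant here reaches a measurable half-maximal value in this assay.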